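The source may hold more compounds than are shown below. What is called first, only, known or untested is meant among the compounds shown, and "the series" means these compounds.

Measured so far in a functional assay on A549 cells (Homo sapiens) for inhibition, read by MTT assay, with a stated time of 72 h; a lower number here means a stronger inhibitor, a higher number a weaker inhibitor:
compound 1 `COC(=O)c1ccc(-n2cc(CCCC(=O)Nc3ccc(C)cc3)nn2)cc1`: 75700 nM
compound 2 `COC(=O)c1ccc(-c2cn(CCCC(=S)Nc3ccc(C)cc3)nn2)cc1`: 50000 nM

Compound 2, at 50000 nM, lies within the scatter of compound 1, so the two cannot be ranked. Among the measured compounds shown here, they also differ in more than one place, which leaves no clean single-change step to draw on.

Compound 3 `Cc1ccc(NC(=S)CCCn2cc(-c3ccc(C(F)(F)F)cc3)nn2)cc1` follows from compound 2 by one change: trifluoromethyl in place of methoxycarbonyl on an aromatic carbon, para to a large group (trifluoromethyl in place of methoxycarbonyl on an aromatic carbon). For the measured compounds named here, no measured pair shows what this exchange does in this assay, so no step beyond the scatter is expected, in either direction. The estimate therefore stays close to compound 2 at 50000 nM as its only anchor. The expected change is small, with a 1.3-fold lower number from compound 2 to compound 3 (0.10 log units; within the scatter) as the estimated step. For compound 3 the expected value is 40000 nM, with an estimated range from 15000 nM to 100000 nM.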

Compound 3, half-maximal inhibitory concentration: 5500 nM
Estimate against measurement, compound 3: 7.3-fold (0.86 log units) above; measured number outside the range, below it.
By their numbers in this assay, from the lowest: compound 3; then compounds 2 and 1 (each within the scatter of the next).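

In this assay, trifluoromethyl in place of methoxycarbonyl on an aromatic carbon, para to a large group, gives a 9.1-fold lower number from compound 2 to compound 3 (0.96 log units; beyond the scatter), the only step shown so far that lies beyond the scatter. Compound 2 and compound 3 differ in this one place alone, so this position is shown to be sensitive to the group it carries, although that rests on a single pair. Nothing available bears on why the number falls with this exchange.

From the compounds shown here alone, whether a nitrile, a chlorine atom or a carboxylic acid at this position would give a lower or a higher number than trifluoromethyl remains open. Going by these compounds, it is also open whether the same exchange on the core of compound 1 would give a step of similar size.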